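Swapping the Chloropyridine for an Oxazole

The source may hold more compounds than are shown below. What is called first, only, known or untested is meant among the compounds shown, and "the series" means these compounds.

Measured so far:
compound 1 `C[C@@H](Oc1cc2ccn(CCC(=O)O)c2cc1Cl)c1ccccn1` — 2.17
compound 2 `C[C@@H](Oc1cc2oc(=O)n(CCC(=O)O)c2cc1Cl)c1ccc(Cl)cn1` — 2.65

Of the compounds shown here, two have been measured in a physicochemical assay for lipophilicity, read by HPLC, at pH 7.4; on this read-out lower numbers stand for lower lipophilicity and higher numbers for higher lipophilicity. Compound 2 stands highest of the two numbers; its nearest neighbour is compound 1, whose value in this assay is lower by a gap beyond the usual scatter. The two differ in several places at once, so nothing can be drawn from that pair about any single change.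

Compound 3 `C[C@@H](Oc1cc2oc(=O)n(CCC(=O)O)c2cc1Cl)c1ncco1` differs from compound 2 in one place: 1,3-oxazol-2-yl in place of 5-chloropyridin-2-yl on a saturated chain carbon bound to an oxygen on an aromatic ring and a saturated chain carbon. The group that leaves carries a chlorine and is larger; the group that enters is smaller and brings one more hydrogen-bond acceptor. On that basis a clear fall in this assay is expected, well beyond the scatter, with the step from compound 2 estimated as a number 1.25 log units lower from compound 2 to compound 3 (beyond the scatter). Compound 3 is therefore expected to come in at about 1.4, within a range from 0.9 to 1.9.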

Compound 3, distribution coefficient: 1.11
The estimate for compound 3 lay 0.29 log units above the measured number; measured number inside the range.
By their numbers in this assay, from the lowest: compound 3; then compound 1; then compound 2.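

Among the compounds shown here, compound 2 and compound 3 differ in one place, so a change in this assay can be tied to a single exchange for the first time: 1,3-oxazol-2-yl in place of 5-chloropyridin-2-yl on the saturated chain carbon gives a number 1.54 log units lower from compound 2 to compound 3 (beyond the scatter). This position is therefore far from silent on this read-out, since exchanging this one group, with the rest of compound 2 unchanged, is enough for a large step. No measurement shown explains the size of this step or separates the part played by the chlorine from that played by the change of ring.

As far as these compounds go, how a 1,3-thiazol-2-yl group or a phenyl ring at this position would compare remains open. So does how this exchange behaves on any other core.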